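The compounds below may be only part of what the source reports. "The series", "measured", "known", "first", "only" and "open" are said of these compounds alone.

Compound 1 `CCCCCCCC/C=C\CCCCCCCCNC(=O)c1c(C)cccc1C`: in an assay on microsomes from intestinal mucosa for inhibition of acyl-CoA:cholesterol acyltransferase (Oryctolagus cuniculus) (on this read-out lower numbers stand for stronger inhibition and higher numbers for weaker inhibition), compound 1 gives 9800 nM.
Compound 2 `CCCCCCCC/C=C\CCCCCCCCNC(=O)Nc1ccccc1`: compound 2 gives > 5000 nM, which is a limit of the assay, not a number.

Compound 2 therefore stands only at a limit, (the limit of > 5000 nM in this assay, at which 1 of the 2 values shown sits), so its place on the scale is not fixed. For this reason the step that the limit leaves unreadable from compound 1 to compound 2 cannot be read. Compound 3 `CCCCCCCC/C=C\CCCCCCCCNC(=O)Nc1ccc(Oc2ccccc2)cc1` differs from compound 2 by phenoxy in place of hydrogen on an aromatic carbon. Among the compounds with values here, the single measured step is the only one bearing on this change, and it yields no size, so nothing measured points to a direction. Compound 3 is expected to give about 3000 nM, within 500 nM to 20000 nM, an expected step of an at least 1.6-fold lower number from compound 2 to compound 3 (0.22 log units; that floor lies within the scatter).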

Compound 3, half-maximal inhibitory concentration: > 5000 nM
Compound 3: only a limit was reported (the forecaster's own chance of this, stated with the estimate: 45%); middle value at least 1.6-fold (0.22 log units) away from the limit.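

No step can be read from compound 2 to compound 3, because both stand only at a limit: the limit of > 5000 nM in this assay, at which 2 of the 3 values shown sit. From the compounds shown here alone, whether phenoxy in place of hydrogen on the aromatic carbon changes inhibition, and by how much, stays open.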